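Swapping the aryl group on the pyrrole core: compound 2 to compound 3

The source may report more compounds than this note shows. Statements on the series, on what has been measured and on what is new or still open speak of the compounds shown alone.

Measured so far:
Compound 1, `COc1cc(C(=O)c2cn(-c3ccc(Br)cc3)cc2-c2ccccc2)cc(OC)c1OC`: 20 nM
Compound 2, `COc1cc(C(=O)c2cn(-c3ccccc3)cc2-c2ccc(Cl)cc2)cc(OC)c1OC`: 290 nM

Both compounds were tested in a functional assay on MCF7 cells (Homo sapiens) for cytotoxicity, read by MTT assay, with a stated time of 96 h; a higher number here means a weaker inhibitor, a lower number a stronger inhibitor. Compound 1 gives 20 nM, and compound 2 gives 290 nM. Of the two numbers, that of compound 2 is the higher one, and its gap to compound 1 lies beyond the usual scatter, so compound 2 is the weaker inhibitor of the pair. Within the data shown here, the two compounds differ in more than one place, so no single step between them can be read off.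

Compound 3, `COc1cc(C(=O)c2cn(-c3ccccc3)cc2-c2cc(F)ccc2F)cc(OC)c1OC`, has not yet been measured. It differs from compound 2 in one place: 2,5-difluorophenyl in place of 4-chlorophenyl on an aromatic carbon. Among the measured compounds shown here, no measured pair shows this exact exchange, so there is no step to lean on. Without such a step, the expectation is a modest change from compound 2 to compound 3 in this assay, not clearly beyond the scatter in either direction. On that basis compound 3 is estimated at 400 nM, within a range of 100 nM to 1600 nM, which corresponds to an expected step of a 1.4-fold higher number from compound 2 to compound 3 (0.14 log units; within the scatter).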

Compound 3, half-maximal inhibitory concentration: 230 nM
Compound 3: the middle estimate sits 1.7-fold (0.24 log units) above what was measured, and the stated range covers the measured number.
By their numbers in this assay, from the lowest: compound 1; then compounds 3 and 2 (each within the scatter of the next).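

In this assay the exchange of 4-chlorophenyl for 2,5-difluorophenyl on this aromatic carbon of the five-membered ring gives a difference that stays within the scatter (a 1.3-fold lower number from compound 2 to compound 3 (0.10 log units; within the scatter)). Among these compounds, this is the first comparison here between compounds that differ in only one place, and it shows that these two substituted phenyl groups cannot be told apart at this position in this test. No supporting data explain why the two compounds read alike.

The steps from compound 1 to the other two cannot be read, since it differs from each of them in more than one place. From the compounds shown here alone, it also stays open whether a phenyl ring carrying an amine or a carboxylic acid would be accepted at this position as well.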